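The source may hold more compounds than are shown below. What is called first, only, known or untested is meant among the compounds shown, and "the series" means these compounds.

Measured so far in an assay on a protein complex for inhibition of ubiquitin carboxyl-terminal hydrolase 1/WD repeat-containing protein 48 (Homo sapiens), read by fluorescence; on this read-out higher numbers stand for weaker inhibition and lower numbers for stronger inhibition:
Compound 1 `Fc1ccc(CNc2nc(-c3ccccc3C(F)(F)F)nc3ccccc23)cc1` gives 3400 nM.
Compound 2 `FC(F)(F)c1ccccc1-c1nc(NCc2ccc(-c3ccc(Cl)c(Cl)c3)cc2)c2ccccc2n1` gives 2200 nM.

Both compounds share one core and differ in a single group. Among the compounds with values here, the one measured step, a 1.5-fold lower number from compound 1 to compound 2 (0.19 log units; within the scatter), lies within the scatter, so compound 2 stands level with compound 1 rather than apart from it.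

Compound 3 `FC(F)(F)c1ccccc1-c1nc(NCc2ccc(-c3ccncc3)cc2)c2ccccc2n1` is the next change: pyridin-4-yl in place of 3,4-dichlorophenyl on an aromatic carbon. Within the data shown here, the only measured step that bears on this part of the molecule is a 1.5-fold lower number from compound 1 to compound 2 (0.19 log units; within the scatter), where a much larger group entered at the same place without any shift beyond the scatter. Going from compound 2 to compound 3, a smaller aromatic ring carrying one hydrogen-bond acceptor enters at that place. Among the measured compounds shown here, with a single small step as the only guide, no movement beyond the scatter is expected in this assay. Compound 3 is therefore expected to give about 3000 nM, within 1000 nM to 9000 nM. The expected step is a 1.4-fold higher number from compound 2 to compound 3 (0.13 log units; within the scatter).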

Compound 3, half-maximal inhibitory concentration: 1900 nM
Beside the measured number, compound 3's estimate is 1.6-fold (0.20 log units) above it, and the stated range covers the measured number.
By their numbers in this assay, from the lowest: compounds 3, 2 and 1 (each within the scatter of the next).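

In this assay, replacing the 3,4-dichlorophenyl group with pyridin-4-yl, a ring that has one hydrogen-bond acceptor and no chlorine, gives a 1.2-fold lower number from compound 2 to compound 3 (0.06 log units; within the scatter), so adding this ring nitrogen and removing both chlorines leaves the read-out level. Set against the small fluoro group of the first compound, the pyridin-4-yl group gives a 1.8-fold lower number from compound 1 to compound 3 (0.25 log units; within the scatter), which means that all three groups seen at this place, two aromatic rings and one single atom, stand level. No supporting evidence is available to explain why the numbers stay so close.

On these data alone, what remains open is whether any group at this place can move the number beyond the scatter, such as a carboxylic acid, a primary amine or a longer alkyl chain. The compounds shown also leave open how much the trifluoromethyl group contributes, since it stays the same throughout.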